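The source may report more compounds than this note shows. Statements on the series, on what has been measured and on what is new or still open speak of the compounds shown alone.

Compound 1, with structure `COc1ccc(/C=C(\C(=O)c2ccc(Br)cc2)S(=O)(=O)c2ccc(Br)cc2)c(F)c1`, was tested in a functional assay on DU-145 cells (Homo sapiens) for inhibition, read by trypan blue exclusion, with a stated time of 96 h (on this read-out higher numbers stand for weaker inhibition of growth and lower numbers for stronger inhibition of growth), where compound 1 gives 10000 nM. Among the three measured compounds this is the second highest number. Its nearest neighbour is compound 3, with structure `COc1ccc(/C=C(/Sc2ccc(Br)cc2)C(=O)c2ccc(Br)cc2)c(F)c1`, which gives 20000 nM; the step of a 2.0-fold higher number from compound 1 to compound 3 (0.30 log units; within the scatter) is within the usual scatter. Further away stands compound 2, with structure `O=C(/C(=C\c1ccc(Br)c(O)c1)Sc1ccc(Br)cc1)c1ccc(Br)cc1`, which in this assay gives 1000 nM.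

The unmeasured compound 4 has structure `Nc1c(Br)cc(Br)cc1/C=C(\C(=O)c1ccc(Br)cc1)S(=O)(=O)c1ccc(Br)cc1`. Compared with compound 1 the change is 2-amino-3,5-dibromophenyl in place of 2-fluoro-4-methoxyphenyl on a double-bonded chain carbon bound to a double-bonded chain carbon. Among the compounds with values here, the one measured step that swaps the group in this same place is a 20-fold higher number from compound 2 to compound 3 (1.30 log units; beyond the scatter), a large move that came with the loss of a 4-bromo-3-hydroxyphenyl group. Since the entering 2-amino-3,5-dibromophenyl group again brings bromine and a hydrogen-bond donor, a move toward stronger inhibition of growth seems more likely than none. Compound 4 is therefore expected to give about 2500 nM, with a range from 500 nM to 12000 nM. The step this estimate implies is a 4.0-fold lower number from compound 1 to compound 4 (0.60 log units; beyond the scatter), and it remains an expectation until compound 4 is measured.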

Compound 4, concentration for 50% growth inhibition: 25000 nM
For compound 4 the middle estimate is 10-fold (1.00 log units) below the measured one; the whole stated range lies below it.
By their numbers in this assay, from the lowest: compound 2; then compounds 1, 3 and 4 (each within the scatter of the next, the first and the last beyond it).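

In this assay, the swap to 2-amino-3,5-dibromophenyl gives a 2.5-fold higher number from compound 1 to compound 4 (0.40 log units; beyond the scatter), so a ring carrying bromine and a hydrogen-bond donor does not by that alone bring stronger inhibition of growth at this place. This is also the only step shown at this place on a compound with the (4-bromophenyl)sulfonyl group, and it is modest, whereas the large step of a 20-fold higher number from compound 2 to compound 3 (1.30 log units; beyond the scatter) belongs to compounds with the (4-bromophenyl)sulfanyl group. Nothing shown explains why the number moves in this direction.

Going by these compounds, it remains open whether the 4-bromo-3-hydroxyphenyl group of compound 2 would also give a low number on the core of compound 1. On these data alone, how a plain phenyl ring or a ring bearing a carboxylic acid would behave at this place also remains open.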